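The source may hold more compounds than are shown below. What is called first, only, known or untested is meant among the compounds shown, and "the series" means these compounds.

Compound 1 `COc1ccc(/C=C\c2cc(OC)c(OC)c(OC)c2)cc1OCc1ccc(CNC(C)(C)C(=O)O)cc1` stands at the edge of what the numbers show. In a functional assay on HeLa cells (Homo sapiens) for antiproliferative activity, read by CCK-8 assay, with a stated time of 48 h (a higher number here means a weaker inhibitor, a lower number a stronger inhibitor), compound 1 gives only a limit, > 10000 nM, so the limit of > 10000 nM in this assay, at which 1 of the 2 values shown sits, is all that is known of it. Compound 2 `COc1ccc(/C=C\c2cc(OC)c(OC)c(OC)c2)cc1OCc1ccc(CO)cc1`, with a hydroxy in place of the (1-carboxy-1-methylethyl)amino group, gives 7600 nM in this assay. That single measured step was an at least 1.3-fold lower number from compound 1 to compound 2 (0.11 log units; that floor lies within the scatter). Compound 3 `COc1ccc(/C=C\c2cc(OC)c(OC)c(OC)c2)cc1OCc1ccc(CN2CCCCC2C(=O)NCCN)cc1` carries a different change: 2-((2-aminoethyl)carbamoyl)piperidin-1-yl in place of (1-carboxy-1-methylethyl)amino on a saturated chain carbon bound to an aromatic carbon. Among the compounds with values here, the one step that bears on it stayed close to the limit, so compound 3 is expected to remain weak, with a step of about an at least 1.2-fold lower number from compound 1 to compound 3 (0.09 log units; that floor lies within the scatter). Compound 3 is estimated at 8000 nM, between 2000 nM and 40000 nM.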

Compound 3, half-maximal inhibitory concentration: 7300 nM
Compound 3: the middle estimate sits 1.1-fold (0.04 log units) above what was measured; the measured number falls inside the stated range.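

In this assay, putting 2-((2-aminoethyl)carbamoyl)piperidin-1-yl in place of hydroxy on the saturated chain carbon gives a 1.0-fold lower number from compound 2 to compound 3 (0.02 log units; within the scatter), so two very different groups at this place read alike. The other new step, an at least 1.3-fold lower number from compound 1 to compound 3 (0.13 log units; that floor lies within the scatter), adds little, as it is only a floor. Compound 1 remains known only through a limit: the limit of > 10000 nM in this assay, at which 1 of the 3 values shown sits. No change at this place has yet moved the number clearly beyond the scatter. Going by these compounds, whether a morpholin-4-yl group or a plain amine on this carbon would do so stays open.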